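Swapping the amine end of a flavone side chain

This account rests on a few compounds, and the source may have more. Where it says the series, first, only, none or still open, it means among the compounds named here.

The compounds share one core, carried here by compound 2 `COc1c(OCCCN2CCN(C)CC2)cc(O)c2c(=O)cc(-c3ccccc3)oc12`. Within the data shown here, in a functional assay on A549 cells (Homo sapiens) for cytotoxicity, read by MTT assay, with a stated time of 48 h (a lower number here means a stronger inhibitor, a higher number a weaker inhibitor), compound 2 gives 9900 nM, and that is the only plain number in the set. Compound 1 `CN(C)CCCCOc1c(O)cc(O)c2c(=O)cc(-c3ccccc3)oc12` is reported only as a limit: in this assay compound 1 gives > 100000 nM, which marks the edge of what the assay reports rather than a measured value, as the limit of > 100000 nM in this assay, at which 1 of the 3 values shown sits, records. Compound 3 `COc1c(O)cc(O)c2c(=O)cc(-c3ccc(Cl)cc3)oc12` carries a chlorine on the pendant phenyl ring, and its result in this assay is "not determined" (no result reported), so it adds nothing to the comparison.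

Compound 4 `COc1c(OCCCCN2CCCC2)cc(O)c2c(=O)cc(-c3ccccc3)oc12` is not yet measured. It differs from compound 2 in one place: (pyrrolidin-1-yl)methyl in place of 4-methylpiperazin-1-yl on a saturated chain carbon, three bonds along the chain from an oxygen on an aromatic ring. Among the measured compounds shown here, no pair of measured compounds differs in a single place, so no measured step is available for comparison; the only guide is that compound 2 holds a finite value where compound 1 reaches only a limit.

On that basis the change from compound 2 to compound 4 is expected to be small, in either direction, and not clearly beyond the scatter, so the estimated step is a 1.2-fold lower number from compound 2 to compound 4 (0.09 log units; within the scatter). For compound 4 in this assay the estimate is 8000 nM, with a range from 3000 nM to 25000 nM.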

Compound 4, half-maximal inhibitory concentration: 1530 nM
Beside the measured number, compound 4's estimate is 5.2-fold (0.72 log units) above it; the whole stated range lies above it.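

Among these compounds, with compound 4, the set gains its only step between two measured compounds. In this assay, moving from 3-(4-methylpiperazin-1-yl)propyl to 4-(pyrrolidin-1-yl)butyl gives the step (a 6.5-fold lower number from compound 2 to compound 4 (0.81 log units; beyond the scatter)), so what stands at the end of this side chain does alter the read-out, and the change here goes towards a stronger inhibitor. The step is a single swap only in name, since the same difference replaces a six-membered non-aromatic ring with two hetero atoms by a five-membered one with a single hetero atom and can equally be read as a change in the chain, so the number belongs to the whole exchange and to neither part alone. No measurement shown here accounts for the size or direction of this step.

On these data alone, what stays open is whether the ring or the chain carries the step, which a 3-(pyrrolidin-1-yl)propyl or a 4-(4-methylpiperazin-1-yl)butyl chain on the same core would help to separate. As far as these compounds go, it is also open how other amine ends, such as a piperidine or a morpholine, would behave on the 4-carbon butyl chain.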